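Replacing 2-Methylphenyl With (Pyridin-3-yl)methyl on the Amide Nitrogen

The source may report more compounds than this note shows. Statements on the series, on what has been measured and on what is new or still open speak of the compounds shown alone.

Compound 1 `COc1cc(-c2cc(C(=O)O)c3ccccc3n2)ccc1OCC(=O)Nc1ccccc1C`: 230000 nM
Compound 2 `COc1cc(-c2cc(C(=O)O)c3ccccc3n2)ccc1OCC(=O)Nc1ccc(Cl)cc1`: > 300000 nM
Compound 3 `COc1cc(-c2cc(C(=O)O)c3ccccc3n2)ccc1OCC(=O)NCc1ccccc1`: > 300000 nM

In an ADME assay on HaCaT cells (Homo sapiens) for inhibition (a higher number here means a weaker inhibitor, a lower number a stronger inhibitor), compound 1 gives 230000 nM. For compound 2 the value > 300000 nM is a limit of the assay rather than a number. For compound 3 the value > 300000 nM is likewise a limit. Among the measured compounds shown here, compound 1 therefore stands as the only real number among the three; the two others sit at the limit of > 300000 nM in this assay, at which 2 of the 3 values shown sit.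

Compound 4 `COc1cc(-c2cc(C(=O)O)c3ccccc3n2)ccc1OCC(=O)NCc1cccnc1` differs from compound 1 in one place: (pyridin-3-yl)methyl in place of 2-methylphenyl on an amide-type nitrogen. For the measured compounds named here, two measured steps bear on this change, both leaving the same group from the same amide nitrogen: an at least 1.3-fold higher number from compound 1 to compound 2 (0.11 log units; that floor lies within the scatter) and an at least 1.3-fold higher number from compound 1 to compound 3 (0.11 log units; that floor lies within the scatter). Each is only a floor that lies within the scatter, so neither shows a clear move. The second step, which also puts a benzyl-type group in place of the aryl group, is the closest model. No step beyond the scatter is expected for this assay, and a limit is the likeliest outcome. Compound 4 is thus estimated at 300000 nM, between 150000 nM and 600000 nM. The expected step is a 1.3-fold higher number from compound 1 to compound 4 (0.12 log units; within the scatter).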

Compound 4, half-maximal inhibitory concentration: > 300000 nM
Compound 4: only a limit was reported; the forecaster's own chance of this, stated with the estimate: 65%; the middle value lies on the limit itself.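

In this assay, putting (pyridin-3-yl)methyl on the amide-type nitrogen gives an at least 1.3-fold higher number from compound 1 to compound 4 (0.11 log units; that floor lies within the scatter), so this change shows no clear move. Compound 4 joins compound 2 and compound 3 at the same limit, so a six-membered aromatic ring with a hetero atom and a hydrogen-bond acceptor brings no readable gain in inhibition here: the limit of > 300000 nM in this assay, at which 3 of the 4 values shown sit. The steps from compound 2 to compound 4 and from compound 3 to compound 4 cannot be read, as each joins two limits.

From the compounds shown here alone, how far compound 2, compound 3 and compound 4 lie past that limit stays open. Also open, going by these compounds, is whether a longer chain ending in an amine, placed on this amide-type nitrogen, would give a real number rather than another limit.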